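The source may report more compounds than this note shows. Statements on the series, on what has been measured and on what is new or still open speak of the compounds shown alone.

Measured compounds:
- compound 1, `C=CCn1c(=O)/c(=C\c2cc(Br)ccc2F)[nH]c(=O)/c1=C\c1ccccc1OC`: 28100 nM
- compound 2, `COc1ccccc1/C=c1\c(=O)[nH]/c(=C/c2cccc(Cl)c2Cl)c(=O)n1C`: 200 nM

Two compounds of the shared core have numbers in a functional assay on MCF7 cells (Homo sapiens) for cytotoxicity, read by CCK-8 assay, with a stated time of 72 h; on this read-out higher numbers stand for weaker inhibition and lower numbers for stronger inhibition. Compound 1 stands at the highest of the two; compound 2, which differs from it in several places, gives 200 nM, and the gap between the two values lies beyond the scatter.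

Compound 3, `C=CCn1c(=O)/c(=C\c2ccc(C)cc2)[nH]c(=O)/c1=C\c1ccccc1OC`, is not yet measured. It differs from compound 1 by 4-methylphenyl in place of 5-bromo-2-fluorophenyl on a double-bonded chain carbon bound to an aromatic carbon. Within the data shown here, no step between measured compounds isolates this change, so the direction rests on compound 1 alone, with its 28100 nM as the anchor. For compound 3 the expected step of a 1.9-fold lower number from compound 1 to compound 3 (0.27 log units; within the scatter) is a modest move toward a lower number, though a result within the scatter of compound 1 is also plausible. The estimate for compound 3 in this assay is 15000 nM, with a range from 3000 nM to 60000 nM.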

Compound 3, half-maximal inhibitory concentration: "not active" (no number reported)
Nothing numeric was reported for compound 3; no gap can be computed for the estimate.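

Among these compounds, compound 3 is reported as "not active" with no number, so no step from compound 1 to compound 3 can be read. Open, from the compounds shown here alone, is how far 4-methylphenyl in place of 5-bromo-2-fluorophenyl shifts the value on the shared core. No supporting data bear on this result.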